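Changing the Aryl Group on the Triazole: Cytotoxicity Unchanged

The compounds below may be only part of what the source reports. "The series", "measured", "known", "first", "only" and "open" are said of these compounds alone.

Three compounds share one core and differ only in the group on the five-membered aromatic ring with 3 nitrogen. In an ADME assay on HeLa cells (Homo sapiens) for cytotoxicity, read by sulforhodamine B assay, with a stated time of 48 h, tested at 10 uM (on this read-out lower numbers stand for less inhibition and higher numbers for more inhibition at the one concentration tested (going by the name of the read-out)), compound 1 `CCCCCCCCc1cn(C(c2ccccc2)c2cc3cc(Br)ccc3nc2OC)nn1` gives 0.1%, compound 2 `COc1nc2ccc(Br)cc2cc1C(c1ccccc1)n1cc(-c2ccc(OC(F)(F)F)cc2)nn1` gives -2.24%, and compound 3 `COc1nc2ccc(Br)cc2cc1C(c1ccccc1)n1cc(-c2ccccc2C(F)(F)F)nn1` gives -1.3%. Compound 3 thus stands second highest of the three, although every gap lies within the scatter. Compound 4 `COc1nc2ccc(Br)cc2cc1C(c1ccccc1)n1cc(-c2ccc(F)cc2)nn1` differs from compound 3 by 4-fluorophenyl in place of 2-(trifluoromethyl)phenyl on an aromatic carbon. Within the data shown here, the steps that bear on this exchange are a number 1.4 percentage points lower from compound 1 to compound 3 (within the scatter) and a number 0.9 percentage points higher from compound 2 to compound 3 (within the scatter), with a number 2.3 percentage points lower from compound 1 to compound 2 (within the scatter) as a further comparison; none left the scatter, so the expected step is a number 0.3 percentage points higher from compound 3 to compound 4 (within the scatter), nothing beyond the scatter. Compound 4 is therefore estimated at -1%, within -8% to 8%.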

Compound 4, a percentage reported as inhibition, at one concentration (the size of the read-out at that concentration, not a potency): 4.27%
Beside the measured number, compound 4's estimate is 5.3 percentage points below it; measured number inside the range.
By their numbers in this assay, from the lowest: compounds 2, 3, 1 and 4 (each within the scatter of the next).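

With 4-fluorophenyl on this aromatic carbon of the five-membered ring, there is a number 5.6 percentage points higher from compound 3 to compound 4 (within the scatter) and a number 6.5 percentage points higher from compound 2 to compound 4 (within the scatter) and also a number 4.2 percentage points higher from compound 1 to compound 4 (within the scatter) in this assay at the one concentration tested. The single fluoro on a phenyl ring therefore joins octyl and the two larger fluorinated groups in leaving every step at this position within the scatter. Nothing measured here accounts for these numbers. Still open, on these data alone, is whether an amine or a carboxylic acid on this carbon would give a step beyond the scatter.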